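The source may report more compounds than this note shows. Statements on the series, on what has been measured and on what is new or still open speak of the compounds shown alone.

Three compounds share one core and differ only in the aryl group carried by the amide-type nitrogen. In a functional assay on MDA-MB-231 cells (Homo sapiens) for inhibition, read by sulforhodamine B assay, with a stated time of 48 h, tested at 1 uM (a higher number here means a weaker effect of the compound at the concentration tested, a lower number a stronger effect), compound 1 `COc1cc(Cl)cc(-c2nn(-c3cccc(NC(=O)Nc4ccc(Cl)c(C(F)(F)F)c4)c3)cc2-c2ccncc2)c1` gives 69%. Compound 2 `COc1cc(Cl)cc(-c2nn(-c3cccc(NC(=O)Nc4ccc(Cl)c(Cl)c4)c3)cc2-c2ccncc2)c1` gives 85%, and compound 3 `COc1cc(Cl)cc(-c2nn(-c3cccc(NC(=O)Nc4cccc(C(F)(F)F)c4)c3)cc2-c2ccncc2)c1` gives 71%. Compound 3 thus stands second highest of the three, within the scatter of compound 1 through a number 2 percentage points higher from compound 1 to compound 3 (within the scatter) and beyond it against compound 2 through a number 14 percentage points lower from compound 2 to compound 3 (beyond the scatter). Compound 4 `COc1cc(Cl)cc(-c2nn(-c3cccc(NC(=O)c4cccc(C(F)(F)F)c4)c3)cc2-c2ccncc2)c1` differs from compound 3 by 3-(trifluoromethyl)phenyl in place of (3-(trifluoromethyl)phenyl)amino on a carbonyl carbon. For the measured compounds named here, no measured step touches this part of the molecule; each, including a number 16 percentage points higher from compound 1 to compound 2 (beyond the scatter), only swaps a substituent on the aryl ring, so there is no direct precedent. The step expected is a number 4 percentage points higher from compound 3 to compound 4 (within the scatter), small and uncertain. Compound 4 is estimated at 75%, between 55% and 95%.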

Compound 4, a percentage reported as activity, at one concentration (the size of the read-out at that concentration, not a potency): 58%
The estimate for compound 4 lay 17 percentage points above the measured number; measured number inside the range.
By their numbers in this assay, from the lowest: compound 4; then compounds 1 and 3 (each within the scatter of the next); then compound 2.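

For the compounds shown here, the amino link on the carbonyl carbon can be removed without losing the effect, and the effect gets stronger: in this assay there is a number 13 percentage points lower from compound 3 to compound 4 (beyond the scatter), the first step here that changes the link rather than a ring substituent. Compound 4 also sits beyond the scatter of the other two, with a number 11 percentage points lower from compound 1 to compound 4 (beyond the scatter) and a number 27 percentage points lower from compound 2 to compound 4 (beyond the scatter), although these two steps change the ring substituents as well. No measurement given here explains this gain.

On these data alone, it remains open whether a methylene group or an ether oxygen in place of the amino nitrogen would behave like compound 4. Also open, as far as these compounds go, is how a 3,4-dichlorophenyl ring would fare directly on the carbonyl carbon.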